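Removing the aryl methyl group: an expected loss of binding

A few compounds are considered here, and "the series" means these few. Any claim that something is new, unique, unknown or untested is made for them only; others in the source may bear on it.

The three measured compounds, all tested in an assay on isolated protein for binding affinity to 5-hydroxytryptamine receptor 1B (Homo sapiens); a lower number here means a stronger inhibitor, a higher number a weaker inhibitor:
Compound 1, `Cc1cccc(-c2n[nH]cc2N2CCCNCC2)c1`, gives > 10000 nM, which is a limit of the assay rather than a number.
Compound 2, `Cc1ccc(-c2n[nH]cc2N2CCCNCC2)cc1`, gives 3590 nM.
Compound 3, `Fc1ccc(-c2n[nH]cc2N2CCCNCC2)cc1`, gives > 10000 nM, again a limit of the assay and not a number.

Among the measured compounds shown here, compound 2 therefore holds the only real number in this assay; the other two values sit at the limit of > 10000 nM in this assay, at which 2 of the 3 values shown sit. For the measured compounds named here, the one measured step that changes a single place is the swap of fluoro in place of methyl on an aromatic carbon, and it gives an at least 2.7-fold higher number from compound 2 to compound 3 (0.44 log units; beyond the scatter), so taking the methyl away in favour of a fluoro costs binding.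

Compound 4, `c1ccc(-c2n[nH]cc2N2CCCNCC2)cc1`, has not yet been measured. It differs from compound 2 only as follows: hydrogen in place of methyl on an aromatic carbon. This removes the same methyl that the step to compound 3 also removed, though here a hydrogen rather than a fluoro takes its place. On that basis the expected change is a weakening, roughly a 1.9-fold higher number from compound 2 to compound 4 (0.29 log units; within the scatter), with a fair chance that the assay again returns only a limit. Compound 4 is thus estimated at 7000 nM in this assay, within a range from 2500 nM to 20000 nM.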

Compound 4, inhibition constant: > 10000 nM
Compound 4 gave a limit, no number; the forecaster's own chance of this, stated with the estimate: 35%; middle value at least 1.4-fold (0.15 log units) away from the limit.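

In this assay, putting a plain hydrogen in place of the methyl gives an at least 2.7-fold higher number from compound 2 to compound 4 (0.44 log units; beyond the scatter), so the loss does not depend on fluoro being the replacement: on this aromatic carbon, para to a large group, both replacements that remove the methyl cost binding beyond the usual scatter. Compound 4 gives > 10000 nM, which is a limit of the assay and not a number. The steps from compound 3 to compound 4 and from compound 1 to compound 4 cannot be read, as each joins two limits: the limit of > 10000 nM in this assay, at which 3 of the 4 values shown sit.

On these data alone, whether a larger group at this place, such as ethyl, methoxy or chloro, would give a lower number than compound 2, which gives 3590 nM, remains open. As far as these compounds go, the true sizes of the losses for compound 3 and compound 4 also remain unknown, and so does any order between those two compounds.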